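This account rests on a few compounds, and the source may have more. Where it says the series, first, only, none or still open, it means among the compounds named here.

Measured compounds:
- compound 1, `Nc1nc(Cl)c2ncn(Cc3ccccc3CCl)c2n1`, 26900 nM in a functional assay on MDA-MB-435 cells (Homo sapiens) for cytotoxicity, read by sulforhodamine B assay, with a stated time of 48 h; on this read-out lower numbers stand for stronger inhibition of growth and higher numbers for weaker inhibition of growth
- compound 2, `ClCc1cccc(Cn2cnc3nc(Cl)nc(Cl)c32)c1`, 2810 nM in this assay

Of the two measured compounds, compound 1 stands at the higher number, that is the weaker growth inhibition, and compound 2 stands at the lower number; the two values differ by more than the usual scatter. Compound 2 differs from compound 1 in more than one place, so its value only shows where a compound with two chloro groups on the shared core can stand.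

Compound 3, `ClCc1ccccc1Cn1cnc2c(Cl)nc(Cl)nc21`, has not yet been measured. It keeps the benzyl arrangement of compound 1 and changes the core in one place: chloro in place of amino on an aromatic carbon. After this change compound 3 carries two chloro groups on the core, as compound 2 does. The step is expected to move toward stronger growth inhibition, that is a lower number, estimated at a 4.5-fold lower number from compound 1 to compound 3 (0.65 log units; beyond the scatter), since compound 2 gives 2810 nM. For compound 3 the expected value is 6000 nM, within a range of 1500 nM to 25000 nM.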

Compound 3, concentration for total growth inhibition: 3230 nM
Estimate against measurement, compound 3: 1.9-fold (0.27 log units) above; the range from low to high includes it.
By their numbers in this assay, from the lowest: compounds 2 and 3 (each within the scatter of the next); then compound 1.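

Going by these compounds alone, this is the first comparison in which only one place changes: with chloro in place of amino on the aromatic carbon between two ring nitrogen atoms, this assay shows an 8.3-fold lower number from compound 1 to compound 3 (0.92 log units; beyond the scatter). The benzyl arrangement stays the same in this pair, so the change in growth inhibition goes with this one position on the core. Nothing measured here says what lies behind the step, or whether losing the amino group or gaining the chloro group counts for more.

On these data alone, it remains open whether other groups on this carbon, such as a methoxy group, a methylamino group or a fluoro group, would stand nearer to compound 1 or to compound 3. As far as these compounds go, it is also open whether the same change gives a step of similar size with the chloromethyl group on the benzyl ring moved elsewhere or replaced by a longer chain.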